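A few compounds are considered here, and "the series" means these few. Any claim that something is new, unique, unknown or untested is made for them only; others in the source may bear on it.

Compound 1 (`O=C1/C(=C/c2ccc(F)cc2)CCC/C1=C\c1ccccc1[N+](=O)[O-]`) in a functional assay on HL-60 cells (Homo sapiens) for cytotoxicity, with a stated time of 24 h (on this read-out higher numbers stand for lower toxicity in this test and lower numbers for higher toxicity in this test), gives 3000 nM
Compound 2 (`CN(C)c1ccc(/C=C2\CCC/C(=C\c3ccccc3[N+](=O)[O-])C2=O)cc1`) gives > 400000 nM as a limit of the assay, not a number
Compound 3 (`O=C1/C(=C/c2ccccc2)CCC/C1=C\c1cccc([N+](=O)[O-])c1`) gives 3000 nM

Compound 3 stands level with compound 1 on these numbers. Compound 4 (`Cc1ccc(/C=C2\CCC/C(=C\c3cccc([N+](=O)[O-])c3)C2=O)cc1`) differs from compound 3 by one change (methyl in place of hydrogen on an aromatic carbon), methyl in place of hydrogen on an aromatic carbon. Going by the values given here, the one measured step (an at least 130-fold higher number from compound 1 to compound 2 (2.12 log units; beyond the scatter)) put dimethylamino in place of fluoro on an aromatic carbon, and it was large. It involves other groups, so it shows that a swap on such a carbon can matter but gives no size for this one. From the compounds shown here alone, no change beyond the scatter is therefore expected in this assay for this swap, and the direction stays open. The estimated step is small (a 1.2-fold higher number from compound 3 to compound 4 (0.07 log units; within the scatter)). Compound 4 is expected at 3500 nM (estimated range 1200 nM to 12000 nM).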

Compound 4, half-maximal cytotoxic concentration: 38000 nM
For compound 4 the middle estimate is 11-fold (1.04 log units) below the measured one; measured number outside the range, above it.
By their numbers in this assay, from the lowest: compounds 1 and 3 (each within the scatter of the next); then compound 4. At a limit, above all of these: compound 2.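

Going from phenyl to 4-methylphenyl gives a 13-fold higher number from compound 3 to compound 4 (1.10 log units; beyond the scatter) in this assay, so a single added carbon on this aromatic ring, para to a large group, is enough to lower toxicity in this test. The earlier compounds shown here showed only that swapping fluoro for dimethylamino on such a carbon can matter, whereas this step gives a size for methyl itself. Nothing measured here explains why so small a change has so large an effect. From the compounds shown here alone, whether an ethyl chain or an amine at this place would move the number further, or back, stays open.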